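A few compounds are considered here, and "the series" means these few. Any claim that something is new, unique, unknown or untested is made for them only; others in the source may bear on it.

Within the data shown here, compound 3 `CCc1ccc(C(=O)Nc2cccc(NC(=O)COc3ccc4c(=O)ccoc4c3)c2)cc1` is the strongest-looking of the measured compounds so far: in an assay on isolated protein for inhibition of Rho-associated protein kinase 1 (Homo sapiens), read by scintillation counting, radiometric assay and 33P incorporation, with a stated time of 40 min, in the presence of a further agent that is not named here (a higher number here means a weaker inhibitor, a lower number a stronger inhibitor), compound 3 gives 235 nM, the lowest number recorded. Compound 1 `COc1cc(OCC(=O)Nc2cccc(NC(=O)c3ccc(N(C)C)cc3)c2)ccc1C=O` carries a different group on the ether side of the shared core, and in this assay compound 1 gives 3740 nM. Compound 2 `CN(C)c1ccc(C(=O)Nc2cccc(NC(=O)COc3ccc4occc(=O)c4c3)c2)cc1` is reported in this assay only as a limit, > 10000 nM. That limit is described by the limit of > 10000 nM in this assay, at which 1 of the 3 values shown sits. Among the measured compounds shown here, the one measured step, an at least 2.6-fold higher number from compound 1 to compound 2 (0.42 log units; beyond the scatter), concerns the group on an oxygen on a saturated carbon and not the ring that distinguishes compound 4 from compound 3.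

Compound 4 `O=C(COc1ccc2c(=O)ccoc2c1)Nc1cccc(NC(=O)c2ccc(OC(F)(F)F)cc2)c1` is not yet measured. It differs from compound 3 by trifluoromethoxy in place of ethyl on an aromatic carbon. For the measured compounds named here, no measured step touches this ring, so there is no basis for expecting a change beyond the scatter, and the expected step is a 1.3-fold higher number from compound 3 to compound 4 (0.11 log units; within the scatter). Compound 4 is therefore estimated at 300 nM, with a range from 90 nM to 1000 nM.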

Compound 4, half-maximal inhibitory concentration: 869 nM
Estimate against measurement, compound 4: 2.9-fold (0.46 log units) below; the measured number falls inside the stated range.
By their numbers in this assay, from the lowest: compound 3; then compound 4; then compound 1. At a limit, above all of these: compound 2.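

Among these compounds, until now, the only measured step concerned the group on the ether side of the shared core. This result shows that the group on an aromatic carbon, para to a large group, also counts in this assay: 4-(trifluoromethoxy)phenyl in place of 4-ethylphenyl gives a 3.7-fold higher number from compound 3 to compound 4 (0.57 log units; beyond the scatter). Nothing measured here accounts for the size or direction of this modest step.

Among the compounds shown here, with only two groups compared at this place, it remains open whether a methoxy group, an amine or a longer chain such as propyl would give a lower or a higher number than ethyl. As far as these compounds go, it also remains open whether the same change would give a step of similar size on a compound carrying a different group on the ether side.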